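The source may report more compounds than this note shows. Statements on the series, on what has been measured and on what is new or still open speak of the compounds shown alone.

Measured compounds:
compound 1 `Cn1cc(-c2nc3ccccc3n2C(=O)c2ccccc2)c2ccccc21` gives 42300 nM
compound 2 `COc1cccc(C(=O)n2c(-c3cn(C)c4ccccc34)nc3ccccc32)c1` gives 13600 nM
compound 3 `COc1ccc(C(=O)n2c(-c3cn(C)c4ccc(Br)cc34)nc3ccccc32)cc1OC` gives 9700 nM

All three values come from a functional assay on HepG2 cells (Homo sapiens) for inhibition, read by MTT assay, with a stated time of 24 h; a higher number here means a weaker inhibitor of growth, a lower number a stronger inhibitor of growth. From compound 1 to compound 2 the change is methoxy in place of hydrogen on an aromatic carbon and the result was a 3.1-fold lower number from compound 1 to compound 2 (0.49 log units; beyond the scatter). Compound 4 `COc1cc(C(=O)n2c(-c3cn(C)c4ccc(Br)cc34)nc3ccccc32)cc(OC)c1OC` is not yet measured; relative to compound 3 it carries methoxy in place of hydrogen on an aromatic carbon. This is the same kind of change as before, not the same: in compound 4 the entering group is ortho to a methoxy group, meta to a large group and meta to a methoxy group, whereas in compound 2 it is meta to a large group only. The difference between the core of compound 1 and the core of compound 3 is not broken down here. In this assay the step from compound 3 to compound 4 is expected to be a 1.8-fold lower number from compound 3 to compound 4 (0.25 log units; within the scatter), smaller than the earlier step, since compound 3 already gives 9700 nM and the surroundings of the new group differ. Compound 4 is estimated at 5500 nM, expected between 2500 nM and 12000 nM.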

Compound 4, concentration for 50% growth inhibition: 8200 nM
Compound 4: the middle estimate sits 1.5-fold (0.17 log units) below what was measured; measured number inside the range.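

In this assay, methoxy in place of hydrogen on an aromatic carbon gives a 1.2-fold lower number from compound 3 to compound 4 (0.07 log units; within the scatter), so on this core the added group leaves the number within the scatter. Set beside the earlier step, the two results do not separate: the same change on two cores in this assay, a 3.1-fold lower number (0.49 log units; beyond the scatter) from compound 1 to compound 2 and a 1.2-fold lower number (0.07 log units; within the scatter) from compound 3 to compound 4, 2.6-fold (0.42 log units) apart, within the scatter of two such steps. Among the compounds shown here, only one pair per core is at hand, and only in compound 4 is the entering methoxy ortho to a methoxy group, so the data show neither that the change carries over unchanged nor that its size depends on the core.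

The compounds shown leave open what the bromine on the core contributes on its own. Also open, from the compounds shown here alone, is whether an amine or a carboxylic acid in place of a methoxy group would shift the number in this assay.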